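The source may hold more compounds than are shown below. What is called first, only, known or untested is meant among the compounds shown, and "the series" means these compounds.

Measured so far in a functional assay on HT-29 cells (Homo sapiens) for antiproliferative activity, read by sulforhodamine B assay, with a stated time of 48 h; on this read-out higher numbers stand for weaker inhibition and lower numbers for stronger inhibition:
- compound 1 `O=C1NCCN1c1ccc(S(=O)(=O)Nc2ccc(C3CCCCC3)cc2)cc1` gives > 1000 nM as a limit of the assay
- compound 2 `Cc1cccc(NS(=O)(=O)c2ccc(N3CCNC3=O)cc2)c1` gives 110 nM as a measured number

Among the compounds with values here, compound 2 therefore holds the only actual number in this small set. Compound 1 is known only through its limit. Compound 3 `Cc1ccc(NS(=O)(=O)c2ccc(N3CCNC3=O)cc2)cc1` has not yet been measured. It differs from compound 2 by 4-methylphenyl in place of 3-methylphenyl on a sulfonamide nitrogen with 4-methylphenyl in place of 3-methylphenyl on a sulfonamide nitrogen. Within the data shown here, the two have the same atoms, joined differently, and no measured step shows what such a change does. No step beyond the scatter is therefore expected in this assay and no direction is favoured. The estimated 1.3-fold higher number from compound 2 to compound 3 (0.10 log units; within the scatter) is expected to stay within the usual scatter. For compound 3 the estimated value is 140 nM with an expected range from 45 nM to 450 nM in this read-out.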

Compound 3, half-maximal inhibitory concentration: 480 nM
Compound 3: middle estimate off by 3.4-fold (0.54 log units), on the low side; measured number above the stated range.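

In this assay, 4-methylphenyl in place of 3-methylphenyl on a sulfonamide nitrogen gives a 4.4-fold higher number from compound 2 to compound 3 (0.64 log units; beyond the scatter), so this position distinguishes between two groups with the same atoms that differ only in how they are joined. Methyl in place of cyclohexyl on an aromatic carbon gives an at least 2.0-fold lower number from compound 1 to compound 3 (0.31 log units; beyond the scatter), which adds a second change on the same position and shows that the number there also responds to the group carried by the aromatic ring. Compound 1 enters that step only through a limit: the limit of > 1000 nM in this assay, at which 1 of the 3 values shown sits.

From the compounds shown here alone, whether the higher number follows the 4-methylphenyl group alone, or whether a plain phenyl or a methoxyphenyl group would fall nearer compound 2, remains open. Going by these compounds, the full size of the step from cyclohexyl to methyl also remains open.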